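Swapping Methoxy for Methyl on the Aromatic Ring

The source may hold more compounds than are shown below. What is called first, only, known or untested is meant among the compounds shown, and "the series" means these compounds.

Measured so far in an ADME assay on HEK293 cells (Homo sapiens) for cytotoxicity, read by MTT assay, with a stated time of 72 h; a higher number here means a weaker inhibitor, a lower number a stronger inhibitor:
- compound 1 `Cc1ccc(C(=O)N2CCN(CC(=O)N3CCN(CCCc4c[nH]c5ccccc45)CC3)CC2)cc1`: 159000 nM
- compound 2 `O=C(CN1CCN(C(=O)c2ccc(Cl)cc2)CC1)N1CCN(CCCc2c[nH]c3ccc(F)cc23)CC1`: 44500 nM
- compound 3 `COc1ccc(C(=O)N2CCN(CC(=O)N3CCN(CCCc4c[nH]c5ccc(F)cc45)CC3)CC2)cc1`: 141000 nM

Compound 3 gives 141000 nM, which lies within the scatter of compound 1 at 159000 nM. Only compound 2 stands apart from this pair, and the numbers for the other two are clearly higher.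

The next compound is compound 4 `Cc1ccc(C(=O)N2CCN(CC(=O)N3CCN(CCCc4c[nH]c5ccc(F)cc45)CC3)CC2)cc1`. It differs from compound 3 by methyl in place of methoxy on an aromatic carbon, which is methyl in place of methoxy on an aromatic carbon, para to a large group.

Two measurements bear on this change. Among the measured compounds shown here, the only measured step at this place is a 3.2-fold higher number from compound 2 to compound 3 (0.50 log units; beyond the scatter), a modest one, and it shows that a swap here can move the number in this assay. However, that step starts from chloro, and no measured step runs from methoxy to methyl. Though without the fluorine of compound 4, compound 1 already carries the 4-methylphenyl group, and compound 1 gives 159000 nM. On that reading, no step beyond the scatter is expected.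

The estimated change is a 1.1-fold lower number from compound 3 to compound 4 (0.05 log units; within the scatter). For compound 4 the expected value is 125000 nM, with an estimated range from 60000 nM to 240000 nM.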

Compound 4, half-maximal inhibitory concentration: 141000 nM
Compound 4: the middle estimate sits 1.1-fold (0.05 log units) below what was measured; the range from low to high includes it.
By their numbers in this assay, from the lowest: compound 2; then compounds 3, 4 and 1 (each within the scatter of the next).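

In this assay, methoxy and methyl at this aromatic carbon, para to a large group, cannot be told apart (no change at the digits printed from compound 3 to compound 4 (within the scatter)), whereas chloro stands apart from methyl (a 3.2-fold higher number from compound 2 to compound 4 (0.50 log units; beyond the scatter)) just as it does from methoxy (a 3.2-fold higher number from compound 2 to compound 3 (0.50 log units; beyond the scatter)). Among the three groups seen at this place, therefore, only the chloro compound gives a separate number, and this now holds against two different groups rather than one. With the 4-methylphenyl group held fixed, the fluoro in place of hydrogen on the other aromatic ring also leaves the two numbers within the scatter (a 1.1-fold lower number from compound 1 to compound 4 (0.05 log units; within the scatter)), and no measurement at hand accounts for any of these results.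

From the compounds shown here alone, it remains open whether chloro is a lone exception at this carbon or whether other groups, such as an amine, a carboxylic acid, a nitrile or a longer chain, would also separate from methoxy and methyl. Going by these compounds, the fluoro step rests on a single pair, so whether it would read the same alongside the 4-methoxyphenyl group or the chloro group also remains open.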